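The compounds below may be only part of what the source reports. "The series", "measured", "known", "first", "only" and "open" are said of these compounds alone.

Measured so far in an assay on isolated protein for inhibition of tyrosine-protein kinase receptor UFO (Homo sapiens), read by FRET and Z'-LYTE, with a stated time of 1.5 h; on this read-out lower numbers stand for stronger inhibition and higher numbers for weaker inhibition:
Compound 1 `Cc1c(C(=O)Nc2ccc(Oc3ncnc4[nH]cc(-c5ccccc5)c34)c(F)c2)c(=O)c2ccccc2n1C` gives a limit of > 10000 nM.
Compound 2 `CCc1ccc2c(c1)c(=O)c(C(=O)Nc1ccc(Oc3ncnc4[nH]cc(-c5ccccc5)c34)c(F)c1)c(C)n2C` gives 6 nM.
Compound 3 `C=C(C)c1ccc2c(c1)c(=O)c(C(=O)Nc1ccc(Oc3ncnc4[nH]cc(-c5ccccc5)c34)c(F)c1)c(C)n2C` gives 170 nM.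

Compound 3 holds the highest of the two numbers; its nearest neighbour is compound 2, with a 28-fold higher number from compound 2 to compound 3 (1.45 log units; beyond the scatter). The value of compound 1 is the limit of > 10000 nM in this assay, at which 1 of the 3 values shown sits.

Compound 4 `Cc1c(C(=O)Nc2ccc(Oc3ncnc4[nH]cc(-c5ccccc5)c34)c(F)c2)c(=O)c2cc(C(C)(C)C)ccc2n1C` differs from compound 3 by tert-butyl in place of 1-methylethenyl on an aromatic carbon. Among the compounds with values here, the steps that bear on it are an at least 1600-fold lower number from compound 1 to compound 2 (3.22 log units; beyond the scatter), an at least 58-fold lower number from compound 1 to compound 3 (1.76 log units; beyond the scatter) and a 28-fold higher number from compound 2 to compound 3 (1.45 log units; beyond the scatter): of the two groups measured at this carbon, the one without the double bond gave the much lower number. Compound 4 carries a group without a double bond, so a lower number is expected, a 3.4-fold lower number from compound 3 to compound 4 (0.53 log units; beyond the scatter), though not the whole way back to compound 2 given the larger group. Compound 4 is estimated in this assay at 50 nM, range 8 nM to 400 nM.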

Compound 4, half-maximal inhibitory concentration: 42 nM
Compound 4: middle estimate off by 1.2-fold (0.08 log units), on the high side, and the stated range covers the measured number.
By their numbers in this assay, from the lowest: compound 2; then compound 4; then compound 3. At a limit, above all of these: compound 1.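

Replacing 1-methylethenyl with tert-butyl gives a 4.0-fold lower number from compound 3 to compound 4 (0.61 log units; beyond the scatter), yet tert-butyl falls short of ethyl, with a 7.0-fold higher number from compound 2 to compound 4 (0.85 log units; beyond the scatter), so the absence of a double bond at this aromatic carbon does not alone return the number of compound 2. Tert-butyl still keeps a far lower number than hydrogen, with an at least 230-fold lower number from compound 1 to compound 4 (2.37 log units; beyond the scatter). That step rests on compound 1, whose value is a limit: the limit of > 10000 nM in this assay, at which 1 of the 4 values shown sits.

Open, on these data alone, is how a methoxy group or an amine at this carbon would rank. Also open, as far as these compounds go, is whether a longer chain such as propyl would match ethyl.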